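Swapping Fluorine Positions on an Aryl Group

The source may report more compounds than this note shows. Statements on the series, on what has been measured and on what is new or still open speak of the compounds shown alone.

Three compounds have been measured in an assay on CHO cells for displacement of a labelled ligand from adenosine receptor A3 (Homo sapiens), read by scintillation counting, tested at 10 uM; on this read-out higher numbers stand for more inhibition at the one concentration tested (going by the name of the read-out) and lower numbers for less inhibition:

compound 1, `CC(C)(C)Cc1c(-c2ccccn2)sc(N)c1C(=O)c1ccc(Cl)cc1`, 1%
compound 2, `CC(C)(C)Cc1c(-c2ccc(F)cc2)sc(N)c1C(=O)c1ccc(Cl)cc1`, 9%
compound 3, `CC(C)(C)Cc1c(-c2ccc(F)cc2F)sc(N)c1C(=O)c1ccc(Cl)cc1`, 1%

Compound 3 stands level with compound 1 at the digits given, and the two share the lowest value of the three; compound 2 lies a number 8 percentage points higher from compound 1 to compound 2 (within the scatter), a gap that is within the scatter. Every change so far concerns the group on the same aromatic carbon: no change at the digits printed from compound 1 to compound 3 (within the scatter) and a number 8 percentage points lower from compound 2 to compound 3 (within the scatter), both within the scatter as well.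

Compound 4, `CC(C)(C)Cc1c(-c2cc(F)ccc2F)sc(N)c1C(=O)c1ccc(Cl)cc1`, is not yet measured. It differs from compound 3 in one place: 2,5-difluorophenyl in place of 2,4-difluorophenyl on an aromatic carbon. Going by the values given here, no measured pair shows this particular swap, but all three measured steps alter the group on that carbon and none moves the read-out beyond the scatter. On that basis the expected step is a number 2 percentage points higher from compound 3 to compound 4 (within the scatter), nothing beyond the scatter. Compound 4 is therefore estimated at 3% in this assay, with a range from 0% to 15%.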

Compound 4, a percentage reported as inhibition, at one concentration (the size of the read-out at that concentration, not a potency): 1%
For compound 4 the middle estimate is 2 percentage points above the measured one; low and high end bracket the measured number.
By their numbers in this assay, from the lowest: compounds 1, 3, 4 and 2 (each within the scatter of the next).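

In this assay, placing 2,5-difluorophenyl instead of 2,4-difluorophenyl on the aromatic carbon next to the ring sulfur gives no change at the digits printed from compound 3 to compound 4 (within the scatter) and so adds a swap of fluorine positions to the changes that leave the read-out within the scatter. Compound 4 also shows a number 8 percentage points lower from compound 2 to compound 4 (within the scatter) and no change at the digits printed from compound 1 to compound 4 (within the scatter), so pyridin-2-yl, 4-fluorophenyl and both difluorophenyl groups at this carbon all stay within the scatter of one another. Nothing available bears on why this position gives so little response to these changes.

From the compounds shown here alone, all four groups at this carbon are six-membered aromatic rings, so it remains open whether a carboxylic acid, an amine or a longer alkyl chain there would move the read-out beyond the scatter. Going by these compounds, it is also open whether replacing the neopentyl group or the (4-chlorophenyl)carbonyl group would do so.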